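This account rests on a few compounds, and the source may have more. Where it says the series, first, only, none or still open, it means among the compounds named here.

Compound 1 `Cc1ccc(-c2nn(CCCCN3CCN(c4ccccc4)CC3)c(=O)c3ccccc23)cc1` gives 23.9 nM in an assay on Cerebral cortex for displacement of a labelled ligand from Adrenergic receptor alpha-1 (Rattus norvegicus); on this read-out higher numbers stand for weaker inhibition and lower numbers for stronger inhibition. Compound 2 `COc1ccccc1N1CCN(CCCCn2nc(-c3ccc(C)cc3)c3ccccc3c2=O)CC1` gives 2.6 nM and compound 3 `Cc1ccc(-c2nn(CCCCN3CCN(c4ccccc4OC(C)C)CC3)c(=O)c3ccccc23)cc1` gives 1.07 nM. Compound 2 thus stands second of the three numbers, with compound 3 beyond the scatter below it and compound 1 beyond the scatter above it. Compound 4 `Cc1ccc(-c2nn(CCCCN3CCN(c4ncccn4)CC3)c(=O)c3ccccc23)cc1` carries pyrimidin-2-yl in place of 2-methoxyphenyl on an amine nitrogen in a ring. Among the compounds with values here, no measured step covers this exchange directly. The nearest are a 9.2-fold lower number from compound 1 to compound 2 (0.96 log units; beyond the scatter) and a 22-fold lower number from compound 1 to compound 3 (1.35 log units; beyond the scatter), in which an alkoxy enters on an aromatic carbon and the number falls, while a 2.4-fold lower number from compound 2 to compound 3 (0.39 log units; beyond the scatter) is modest. Within the data shown here, compound 4 gives up that methoxy, so a move back toward compound 1 is expected, and the pyrimidin-2-yl has no measured counterpart. Compound 4 is therefore expected at 60 nM, within 15 nM to 250 nM, an expected 23-fold higher number from compound 2 to compound 4 (1.36 log units; beyond the scatter).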

Compound 4, inhibition constant: 270 nM
Compound 4: middle estimate off by 4.5-fold (0.65 log units), on the low side; the measured number lies above the stated range.
By their numbers in this assay, from the lowest: compound 3; then compound 2; then compound 1; then compound 4.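

On the amine nitrogen in a ring, pyrimidin-2-yl gives a 100-fold higher number from compound 2 to compound 4 (2.02 log units; beyond the scatter) and a 250-fold higher number from compound 3 to compound 4 (2.40 log units; beyond the scatter) in this assay and still gives an 11-fold higher number from compound 1 to compound 4 (1.05 log units; beyond the scatter) against phenyl with no alkoxy. Loss of the alkoxy therefore does not cover the whole rise, and the exchange of the aromatic ring itself carries part of it. Nothing at hand explains this rise. Open, as far as these compounds go, is whether pyridin-2-yl, with a single ring nitrogen, falls nearer compound 1 or compound 4. Also open, from the compounds shown here alone, is whether a methoxy group on the pyrimidine ring would bring the number back down.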